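The compounds below may be only part of what the source reports. "The series", "measured", "known", "first", "only" and "open" are said of these compounds alone.

Compound 1, `N=C(N)Nc1cccc(C(=O)NNC(=O)NC(CC(=O)O)c2cccc3ccccc23)c1`: in a physicochemical assay for lipophilicity (on this read-out higher numbers stand for higher lipophilicity and lower numbers for lower lipophilicity), compound 1 gives 1.7.
Compound 2, `O=C(O)CC(NC(=O)NNC(=O)CCCCNc1ccccn1)c1ccc(Cl)cc1`: in this assay compound 2 gives 2.2.
Compound 3, `COc1ccc(C(CC(=O)O)NC(=O)NNC(=O)CCCCNc2ccccn2)cc1`: in this assay compound 3 gives 1.52.

Compound 3 stands lowest of the three numbers in this assay. Compound 1 lies nearest to it, within the usual scatter, so no order can be read between those two. For the measured compounds named here, compound 2 lies furthest, and the one measured step, a number 0.68 log units lower from compound 2 to compound 3 (beyond the scatter), describes that gap.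

Compound 4, `O=C(O)CC(NC(=O)NNC(=O)CCCCNc1ccccn1)c1cccc2ccccc12`, differs from compound 3 in one place: naphthalen-1-yl in place of 4-methoxyphenyl on a saturated chain carbon bound to an amide-type nitrogen and a saturated chain carbon. Going by the values given here, the only measured step swaps one group on this same chain carbon for another and is therefore the closest guide, though it concerns a different pair of groups. Among the compounds with values here, compound 1 also carries naphthalen-1-yl, but on a different core, so compound 1 and compound 3 show only two values within the scatter of each other. Replacing a ring that holds one hydrogen-bond acceptor by two aromatic rings of carbon alone is expected to raise the number in this assay beyond the scatter, a step of a number 1.18 log units higher from compound 3 to compound 4 (beyond the scatter). Compound 4 is therefore estimated at 2.7, with a range from 2.2 to 3.2.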

Compound 4, partition coefficient: 2.64
Estimate against measurement, compound 4: 0.06 log units above; low and high end bracket the measured number.
By their numbers in this assay, from the lowest: compounds 3 and 1 (each within the scatter of the next); then compound 2; then compound 4.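

Measured in this assay, naphthalen-1-yl on this chain carbon gives a number 1.12 log units higher from compound 3 to compound 4 (beyond the scatter) and a number 0.44 log units higher from compound 2 to compound 4 (beyond the scatter) as well, so three groups at this place now fall in a clear order: 4-methoxyphenyl lowest, 4-chlorophenyl next, naphthalen-1-yl highest. With naphthalen-1-yl held fixed, changing the group on the carbonyl carbon also moves the number, giving a number 0.94 log units higher from compound 1 to compound 4 (beyond the scatter) and showing that this second place counts as well. No measurement shown gives a reason for these differences.

Where an unsubstituted phenyl or a saturated cyclohexyl would fall in that order at the chain carbon remains open. Also open, going by these compounds, is how the number would respond on the carbonyl side to a shorter or longer chain, or to a primary amine at its end.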